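Bromo for carboxy on the benzylic ring of compound 3

The source may report more compounds than this note shows. Statements on the series, on what has been measured and on what is new or still open speak of the compounds shown alone.

Measured compounds in an assay for inhibition of Indoleamine 2,3-dioxygenase 1 (Homo sapiens), with stated times of 10 min and 60 min, tested at 10 uM; on this read-out lower numbers stand for a weaker effect and higher numbers for a stronger effect at the one concentration tested:
compound 1 `O=[N+]([O-])c1cccc(CNc2cc(C(F)(F)F)cc3[nH]ncc23)c1` gives 45%
compound 2 `FC(F)(F)c1cc(NC[C@H]2CCCN2)c2cn[nH]c2c1` gives 34%
compound 3 `O=C(O)c1cccc(CNc2cc(C(F)(F)F)cc3[nH]ncc23)c1` gives 11%

Compound 3 stands lowest of the three numbers; its nearest neighbour is compound 2, its furthest compound 1, both beyond the scatter. Compound 4 `FC(F)(F)c1cc(NCc2cccc(Br)c2)c2cn[nH]c2c1` differs from compound 3 by bromo in place of carboxy on an aromatic carbon. Among the compounds with values here, the only step that bears on this change is a number 34 percentage points lower from compound 1 to compound 3 (beyond the scatter), which shows that a carboxy on this aromatic carbon goes with a much weaker read-out than a nitro there. Within the data shown here, no measured pair shows bromo directly, so the size of the step remains uncertain, but a move back toward the nitro level is expected. Compound 4 is therefore estimated at 35%, with a range of 15% to 55%, meaning an expected step of a number 24 percentage points higher from compound 3 to compound 4 (beyond the scatter).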

Compound 4, a percentage reported as inhibition, at one concentration (the size of the read-out at that concentration, not a potency): 23%
Estimate against measurement, compound 4: 12 percentage points above; low and high end bracket the measured number.
By their numbers in this assay, from the lowest: compound 3; then compound 4; then compound 2; then compound 1.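

In this assay bromo on this aromatic carbon recovers only part of what carboxy loses against nitro, with a number 12 percentage points higher from compound 3 to compound 4 (beyond the scatter) and a number 22 percentage points lower from compound 1 to compound 4 (beyond the scatter) as its two steps, so all three groups separate beyond the scatter. The comparison with the pyrrolidin-2-yl side chain shows a number 11 percentage points lower from compound 2 to compound 4 (beyond the scatter) when 3-bromophenyl takes its place on the saturated chain carbon. Nothing available gives a reason for these steps.

Open, from the compounds shown here alone, is where an amine or a nitrile on this aromatic carbon would fall relative to bromo and nitro. Also open, going by these compounds, is whether a longer chain to the 3-bromophenyl group would change the read-out.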